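The source may hold more compounds than are shown below. What is called first, only, known or untested is meant among the compounds shown, and "the series" means these compounds.

Of the compounds shown here, two that share one core have been measured in a functional assay on SW1573 cells (Homo sapiens) for antiproliferative activity; a higher number here means a weaker inhibitor of growth, a lower number a stronger inhibitor of growth. Compound 1 `CC(C)CC1OCCC(Cl)=C1[Si](C)(C)C` gives 10000 nM in this assay. Compound 2 `CC(C)CC1C=C(Cl)CCO1` differs from it in one place, and in this assay compound 2 reaches only the limit of the measurement, recorded as > 100000 nM. Between them lies an at least 10-fold higher number from compound 1 to compound 2 (1.00 log units; beyond the scatter); here the limit of > 100000 nM in this assay, at which 1 of the 2 values shown sits, shows that the second number is a boundary and not a measured point, so compound 2 stands at the weak end of what the measurement can report.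

Compound 3 `C#CCCC1C=C(Cl)CCO1` is the compound still to be measured. It differs from compound 2 by propargyl in place of isopropyl on a saturated chain carbon bound to a saturated ring carbon. Among the compounds with values here, none of the measured steps touches this part of the molecule: the only measured step, from compound 1 to compound 2, concerns a different position, and it ran toward weaker growth inhibition. Nothing measured therefore speaks for a gain. Compound 3 is expected to sit near the same boundary, the estimated step being a number no higher from compound 2 to compound 3 (the limit leaves the size open), about none beyond the scatter. The estimate for compound 3 is 100000 nM, with a range from 30000 nM to 300000 nM.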

Compound 3, concentration for 50% growth inhibition: 41000 nM
Compound 3: the middle estimate sits 2.4-fold (0.39 log units) above what was measured; low and high end bracket the measured number.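

Within the data shown here, replacing isopropyl with propargyl on this saturated chain carbon gives an at least 2.4-fold lower number from compound 2 to compound 3 (0.38 log units; beyond the scatter) in this assay and so shows that this part of the molecule, which no earlier step touched, responds to a change of group. The two groups have the same count of heavy atoms and neither carries a ring, so the difference that stands out is the triple bond that propargyl brings, although one pair of compounds cannot tie the step to that bond. From the compounds shown here alone, compound 2 stands at a limit and not at a measured number, so the full size of the step stays unknown: the limit of > 100000 nM in this assay, at which 1 of the 3 values shown sits.

Going by these compounds, it remains open whether the stronger growth inhibition depends on the triple bond itself, or whether a saturated propyl chain, a longer chain or an amine at the end of the chain would serve as well. Also open, on these data alone, is whether propargyl would bring a similar step on the core of compound 1, which keeps the silicon-bearing group on the double-bonded ring carbon.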